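The source may report more compounds than this note shows. Statements on the series, on what has been measured and on what is new or still open speak of the compounds shown alone.

Two ureas on the shared core have numbers in a functional assay on HepG2 cells (Homo sapiens) for antiproliferative activity, read by MTT assay, with a stated time of 48 h; on this read-out higher numbers stand for weaker inhibition and lower numbers for stronger inhibition. Compound 1 `O=C(Nc1cccc(CNc2nccnc2Cl)c1)Nc1cccc2ccccc12` carries a naphthyl urea; in this assay compound 1 gives only a limit, > 40000 nM, which is the limit of > 40000 nM in this assay, at which 1 of the 2 values shown sits. For the measured compounds named here, compound 2 `O=C(Nc1ccccc1)Nc1cccc(CNc2nccnc2Cl)c1` carries a plain phenyl urea; in this assay compound 2 gives 15600 nM, the only actual number in the set, so compound 2 stands as the single measured point. Compound 3 `O=C(Nc1cccc(CNc2nccnc2Cl)c1)Nc1ccc(Cl)cc1Br` is the next member: 2-bromo-4-chlorophenyl in place of phenyl on an amide-type nitrogen. Going by the values given here, no measured step between two compounds is available, so the size of this change is not anchored by any pair with numbers. The expected step from compound 2 to compound 3 is a modest gain, a 2.0-fold lower number from compound 2 to compound 3 (0.29 log units; within the scatter), likely just beyond the usual scatter. For compound 3 the estimate in this assay is 8000 nM, with a range from 2500 nM to 30000 nM.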

Compound 3, half-maximal inhibitory concentration: 6720 nM
For compound 3 the middle estimate is 1.2-fold (0.08 log units) above the measured one; measured number inside the range.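

In this assay, the aryl group on the amide-type nitrogen now has its first measured step: 2-bromo-4-chlorophenyl in place of phenyl gives a 2.3-fold lower number from compound 2 to compound 3 (0.37 log units; beyond the scatter). This shows that the place accepts bromine and chlorine on the ring with a modest move towards stronger inhibition, and the step gives the first measured size for a change at this place. Nothing in the data at hand gives a cause for this step.

Bromine and chlorine enter together, so the share of each stays open, and a ring with only one of them, such as 4-chlorophenyl or 2-bromophenyl, would be needed to separate them. Also open, as far as these compounds go, is how this place responds to a group of another kind on the ring, such as an amine or a carboxylic acid.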